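This account rests on a few compounds, and the source may have more. Where it says the series, first, only, none or still open, it means among the compounds named here.

In a functional assay on a cell-free system (plasma, Oryctolagus cuniculus) for inhibition, with stated times of 5 min, 1 min and 6 min (on this read-out higher numbers stand for weaker inhibition and lower numbers for stronger inhibition), compound 1 (`CCOC(=O)c1c(C)nc(-c2cccc(C#N)c2)n1C`) gives 22100 nM, and compound 2 (`CCOCCOn1c(-c2cccc(C#N)c2)nc(C)c1C(=O)OCC`) gives 6250 nM. Compound 3 (`CCOC(=O)c1c(C)nc(-c2cccc(C#N)c2)n1OCCC(=O)O`) is reported as > 30000 nM, which is a limit of the assay and not a number. Its exact place on the scale is therefore unknown, and it can only be compared with the others through the steps that lead to it.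

Compound 4 (`CCOC(=O)c1c(C)nc(-c2cccc(C#N)c2)n1OCc1cccc(Cl)c1`) keeps the shared core, but 3-chlorophenyl takes the place of carboxymethyl on a saturated chain carbon bound to an oxygen on an aromatic ring: 3-chlorophenyl in place of carboxymethyl on a saturated chain carbon bound to an oxygen on an aromatic ring. Within the data shown here, no measured compound carries 3-chlorophenyl, so the evidence is indirect. Among the measured compounds shown here, three measured steps bear on the change. The first is a 3.5-fold lower number from compound 1 to compound 2 (0.55 log units; beyond the scatter). The second, an at least 1.3-fold higher number from compound 1 to compound 3 (0.13 log units; that floor lies within the scatter), shows that compound 3 does not share the gain seen with compound 2. The third is an at least 4.8-fold higher number from compound 2 to compound 3 (0.68 log units; beyond the scatter), and it is the closest guide, since compound 4, like compound 2, has no carboxy group. A lower number of modest size is therefore expected, and the expected change is an at least 6.0-fold lower number from compound 3 to compound 4 (0.77 log units; beyond the scatter). For compound 4, the estimated value is 5000 nM, with an expected range from 1200 nM to 20000 nM.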

Compound 4, half-maximal inhibitory concentration: 19400 nM
Compound 4: the middle estimate sits 3.9-fold (0.59 log units) below what was measured; measured number inside the range.
By their numbers in this assay, from the lowest: compound 2; then compounds 4 and 1 (each within the scatter of the next). At a limit, above all of these: compound 3.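

The new compound shows that putting an aromatic ring on this oxygen chain does not reproduce the gain seen with the 2-ethoxyethoxy group: in this assay the result is a 3.1-fold higher number from compound 2 to compound 4 (0.49 log units; beyond the scatter). Measured against the methyl group, the (3-chlorobenzyl)oxy group gives a 1.1-fold lower number from compound 1 to compound 4 (0.06 log units; within the scatter), so an oxygen-linked group on the aromatic nitrogen does not by itself lower the number, and of the three such groups shown only the 2-ethoxyethoxy group of compound 2 does so. The step away from the carboxy-bearing chain (an at least 1.5-fold lower number from compound 3 to compound 4 (0.18 log units; that floor lies within the scatter)) starts from a limit of the assay and not a number, so it gives only a floor, and that floor lies within the scatter: the limit of > 30000 nM in this assay, at which 1 of the 4 values shown sits.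

The compounds shown leave open whether the chlorine or the ring of the 3-chlorobenzyl group decides this result, a question that a plain benzyl group on the same oxygen could settle. They also leave open whether the second oxygen in the chain of compound 2 matters, which a pentyl chain in its place could test, and how an amine at the end of that chain would read out.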